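This account rests on a few compounds, and the source may have more. Where it says the series, first, only, none or still open, it means among the compounds named here.

Compound 1 `O=C(CCCc1ccc(Cl)c(Cl)c1)Nc1nc2ccccc2c(=O)s1` carries a 3,4-dichlorophenyl at the end of the chain on the shared core. In an assay on CHO cells for displacement of a labelled ligand from adenosine receptor A2b (Homo sapiens), read by scintillation counting, with a stated time of 75 min (on this read-out lower numbers stand for stronger inhibition and higher numbers for weaker inhibition), compound 1 gives > 1000 nM, a limit of the assay rather than a number. Compound 1 therefore sits at the limit of > 1000 nM in this assay, at which 1 of the 2 values shown sits, and stands only as a range. Compound 2 `O=C(CCCc1ccccc1)Nc1nc2sccc2c(=O)s1` has a different core and an unsubstituted phenyl; in this assay compound 2 gives 361 nM. No step between measured compounds links the two, so their values are simply shown side by side. Compound 3 `O=C(CCCc1cccc(Cl)c1)Nc1nc2ccccc2c(=O)s1` has not been measured. It differs from compound 1 by hydrogen in place of chloro on an aromatic carbon, or, read one bond further out, 3,4-dichlorophenyl to 3-chlorophenyl. The step in this assay is expected to be small, with no clear direction beyond the scatter, and is estimated here as a step that the limit leaves unreadable from compound 1 to compound 3. Compound 3 is accordingly expected to give 1500 nM, between 500 nM and 5000 nM.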

Compound 3, inhibition constant: >= 1000 nM
Compound 3: a limit, no number; the forecaster's own chance of this, stated with the estimate: 50%; the middle value lies beyond the limit too.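

In this assay compound 1 and compound 3 both stand only as limits, so no step can be read between them. The compounds shown leave open whether hydrogen in place of chloro on an aromatic carbon changes the inhibition constant at all, and in which direction.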